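Removing a Methoxy Group From a Selenocyanate Carbamate

A few compounds are considered here, and "the series" means these few. Any claim that something is new, unique, unknown or untested is made for them only; others in the source may bear on it.

Compound 1 `COc1ccc(OC(=O)Nc2ccc([Se]C#N)cc2)cc1` is one of three selenium-containing carbamates tested in a functional assay on MCF7 cells (Homo sapiens) for cytotoxicity, read by MTT assay, with a stated time of 72 h; on this read-out lower numbers stand for stronger inhibition of growth and higher numbers for weaker inhibition of growth. In this assay compound 1 gives 48200 nM, nominally the highest of the three numbers, yet within the scatter of compound 3 `CCCCOC(=O)Nc1ccc([Se][Se]c2ccc(NC(=O)OCCCC)cc2)cc1`, which gives 46300 nM, and of compound 2 `CCOC(=O)Nc1ccc([Se][Se]c2ccc(NC(=O)OCC)cc2)cc1`, which gives 39000 nM. Compound 4 `N#C[Se]c1ccc(NC(=O)Oc2ccccc2)cc1` is not yet measured. It differs from compound 1 in one place: hydrogen in place of methoxy on an aromatic carbon. Going by the values given here, no measured pair shows this change. Because compound 1 gives 48200 nM and the other two values lie within the scatter of it, nothing beyond the scatter is expected. For compound 4 the estimated step is a 1.1-fold lower number from compound 1 to compound 4 (0.03 log units; within the scatter). Compound 4 is expected to give about 45000 nM, likely between 20000 nM and 100000 nM.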

Compound 4, concentration for total growth inhibition: 35900 nM
The estimate for compound 4 lay 1.3-fold (0.10 log units) above the measured number; the measured number falls inside the stated range.
By their numbers in this assay, from the lowest: compounds 4, 2, 3 and 1 (each within the scatter of the next).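

Going by these compounds alone, compound 4 gives the first direct reading of this position: in this assay, hydrogen in place of methoxy on an aromatic carbon gives a 1.3-fold lower number from compound 1 to compound 4 (0.13 log units; within the scatter) and so leaves the two compounds indistinguishable. On the core of compound 1, then, the methoxy group para to a large group can be removed with no difference that stands clear of the scatter.

As far as these compounds go, whether an amine, a carboxylic acid or a longer chain at this position would give a number beyond the scatter remains open. No other data here help to explain this result.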